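Replacing isopropoxy with tert-butyl on compound 1

A few compounds are considered here, and "the series" means these few. Any claim that something is new, unique, unknown or untested is made for them only; others in the source may bear on it.

In an ADME assay on a cell-free system (plasma, Homo sapiens) for metabolic stability, read by LC-MS, with a stated time of 2 h, tested at 1 ug/mL (a lower number here means that less of the compound is left, a higher number that more of the compound is left), compound 1 (`CC(C)OC(=O)OCOC(=O)c1ccc(N)cc1O`) gives 0%. Among the compounds with values here, the only other measured compound, compound 2 (`Cc1oc(=O)oc1COC(=O)c1ccc(N)cc1O`), gives 0%, so compound 1 stands level with it and none of either compound is detected at the end of the test.

Compound 3 (`CC(C)(C)C(=O)OCOC(=O)c1ccc(N)cc1O`) has not been measured yet. It carries tert-butyl in place of isopropoxy on a carbonyl carbon, and the change counts as follows: tert-butyl in place of isopropoxy on a carbonyl carbon.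

Within the data shown here, no measured pair shows what this exact swap does in this assay. Among the measured compounds shown here, the only guide is that compound 1 gives 0% and compound 2 gives 0%, despite their different structures. No change beyond the scatter is therefore expected, and any small movement could only be upward. The estimated step is a number 3 percentage points higher from compound 1 to compound 3 (within the scatter). For compound 3, the expected value is 3%, with an estimated range of 0% to 20%.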

Compound 3, percent of the compound remaining: 15%
Compound 3: middle estimate off by 12 percentage points, on the low side; low and high end bracket the measured number.
By their numbers in this assay, from the lowest: compounds 1 and 2 (each within the scatter of the next); then compound 3.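

Placing tert-butyl instead of isopropoxy on this carbonyl carbon gives a number 15 percentage points higher from compound 1 to compound 3 (beyond the scatter) in this assay, so this position can change how much compound survives, something two readings with nothing left could not reveal. The swap keeps the number of heavy atoms in the group the same but puts a carbon where the oxygen stood, and even so most of compound 3 is gone, with 15% remaining. No measurement here explains the difference between the two groups.

An isopropyl or a tert-butoxy group on the same carbon would help separate the effect of removing the oxygen from that of the branching in tert-butyl. As far as these compounds go, it also remains open whether a cyclohexyl group or an amine at this position would leave more compound intact.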